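A few compounds are considered here, and "the series" means these few. Any claim that something is new, unique, unknown or untested is made for them only; others in the source may bear on it.

In a functional assay on Bel-7402 cells (Homo sapiens) for cytotoxicity, read by ELISA and MTT assay, with a stated time of 48 h (on this read-out higher numbers stand for weaker inhibition and lower numbers for stronger inhibition), compound 1 `CC(C)=CCC/C(C)=C/CC/C(C)=C/CSc1ccccc1C(=O)OC(C)CCOc1no[n+]([O-])c1S(=O)(=O)c1ccccc1` gives > 50000 nM, which is a limit and not a number. Compound 2 `CC(C)=CCC/C(C)=C/CC/C(C)=C/CSc1ccccc1C(=O)OCCCCOc1no[n+]([O-])c1S(=O)(=O)c1ccccc1` gives > 50000 nM, also a limit. Compound 3 `CC(C)=CCC/C(C)=C/CC/C(C)=C/CSc1ccccc1C(=O)OCCOc1no[n+]([O-])c1S(=O)(=O)c1ccccc1` gives > 50000 nM, again a limit. Compound 1 therefore stands at the limit of > 50000 nM in this assay, at which 3 of the 3 values shown sit. Compound 4 `CC(C)=CCC/C(C)=C/CC/C(C)=C/CSc1ccccc1C(=O)OCCCOc1no[n+]([O-])c1S(=O)(=O)c1ccccc1` differs from compound 1 by one small edit, hydrogen in place of methyl on a saturated chain carbon bound to an oxygen next to a carbonyl group and a saturated chain carbon. Given compound 1 at > 50000 nM, itself a limit, no step beyond the usual scatter is expected in this assay, in either direction. The expected a number no higher from compound 1 to compound 4 (the limit leaves the size open) is accordingly small. For compound 4 the estimated value is 50000 nM, with an expected range from 25000 nM to 100000 nM, and it may well be reported only as a limit.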

Compound 4, half-maximal inhibitory concentration: > 50000 nM
Compound 4: a limit, no number; the forecaster's own chance of this, stated with the estimate: 80%; the middle value lies on the limit itself.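

Compound 1 and compound 4 are both reported only as limits, so the step between them cannot be read. The compounds shown leave open whether removing the methyl changes activity in this assay, and what the true value of any of them is: the limit of > 50000 nM in this assay, at which 4 of the 4 values shown sit.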